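From Benzyl to 3-Methoxypropyl: One Change, One Open Value

This account rests on a few compounds, and the source may have more. Where it says the series, first, only, none or still open, it means among the compounds named here.

Three related compounds have been measured in a functional assay on HeLa cells (Homo sapiens) for antiproliferative activity; on this read-out higher numbers stand for weaker inhibition and lower numbers for stronger inhibition. In this test, compound 1 (`Cc1cc2c(F)c(Oc3ncnc(N)c3/C=N/OCc3ccccc3)ccc2[nH]1`) gives 266 nM, compound 2 (`CO/N=C/c1c(N)ncnc1Oc1ccc2[nH]cc(C)c2c1`) gives 306 nM, and compound 3 (`CO/N=C/c1c(N)ncnc1Oc1ccc2[nH]ccc2c1F`) gives 401 nM. These three numbers lie within the usual scatter of one another, so compound 1 sits level with the other two and none of them can be ranked.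

The next molecule, compound 4 (`COCCCO/N=C/c1c(N)ncnc1Oc1ccc2[nH]c(C)cc2c1F`), keeps the core of compound 1 and alters one group: 2-methoxyethyl in place of phenyl on a saturated chain carbon bound to an oxygen. Counted atom by atom, the difference is 2-methoxyethyl in place of phenyl on a saturated chain carbon bound to an oxygen. Seen one bond further out, benzyl gives way to 3-methoxypropyl, so a ring is exchanged for an open chain.

For the measured compounds named here, no measured pair isolates this change, so any forecast is uncertain. Compound 2 and compound 3 differ from compound 1 in more than one place, yet compound 2 at 306 nM and compound 3 at 401 nM remain within the scatter of compound 1. A step beyond the scatter in this assay is therefore not expected. The expected change is a 1.1-fold higher number from compound 1 to compound 4 (0.05 log units; within the scatter). For compound 4, the estimated value is 300 nM, with an expected range from 100 nM to 900 nM.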

Compound 4, half-maximal inhibitory concentration: 346 nM
Estimate against measurement, compound 4: 1.2-fold (0.06 log units) below; the range from low to high includes it.
By their numbers in this assay, from the lowest: compounds 1, 2, 4 and 3 (each within the scatter of the next).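

For the compounds shown here, compound 1 and compound 4 form the first pair here that differs in one place only, so this change can now be read directly. In this assay putting 2-methoxyethyl in place of phenyl on a saturated chain carbon bound to an oxygen gives a 1.3-fold higher number from compound 1 to compound 4 (0.11 log units; within the scatter) and stays inside the normal variation between repeat measurements. At this place, then, a six-membered aromatic ring of carbon can give way to an open chain with no ring and a hydrogen-bond acceptor without a measurable shift in this read-out, though no data shown here explain why the two compounds read alike.

On these data alone, this single pair cannot show how much freedom the place really allows, and it remains open whether an amine, a carboxylic acid or a longer chain on the same carbon would also stay level with compound 1. It also leaves open whether the exchange of benzyl for 3-methoxypropyl would give a similar result on the slightly different cores of compound 2 and compound 3.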